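The compounds below may be only part of what the source reports. "The series", "measured", "known", "first", "only" and "open" are said of these compounds alone.

Compound 1 `Cc1ccc([C@H](C)NC(=O)Cn2nnc3ccccc3c2=O)cc1`: 12000 nM
Compound 2 `Cc1ccc([C@H](C)NC(=O)Cn2nnc3ccccc3c2=O)nc1`: 2000 nM
Compound 3 `Cc1ccc([C@H](C)NC(=O)Cn2nnc3ccccc3c2=O)cn1`: 9800 nM

In a physicochemical assay for solubility, read by HPLC, in phosphate buffer, with a stated time of 16 h, at pH 6.8 (on this read-out higher numbers stand for higher solubility and lower numbers for lower solubility), compound 1 gives 12000 nM, level with one pyridine analogue, a 1.2-fold lower number from compound 1 to compound 3 (0.09 log units; within the scatter), and clear of the other, a 6.0-fold lower number from compound 1 to compound 2 (0.78 log units; beyond the scatter). Compound 4 `Cc1ccc([C@H](C)NC(=O)Cn2nnc3ccc(C)cc3c2=O)cc1` differs from compound 1 by methyl in place of hydrogen on an aromatic carbon of a six-membered aromatic ring of carbon only, part of a fused or bridged system of two rings. Going by the values given here, no measured step touches the shared core, as all three replace the 4-methylphenyl group, so they offer only a rough scale. The largest, a 6.0-fold lower number from compound 1 to compound 2 (0.78 log units; beyond the scatter), suggests a modest expected drop in this assay, possibly within the scatter. The expected change is a 2.0-fold lower number from compound 1 to compound 4 (0.30 log units; within the scatter). For compound 4 the estimated value is 6000 nM, with an expected range of 2000 nM to 15000 nM.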

Compound 4, solubility: 3100 nM
Compound 4: the middle estimate sits 1.9-fold (0.29 log units) above what was measured; measured number inside the range.
By their numbers in this assay, from the lowest: compounds 2 and 4 (each within the scatter of the next); then compounds 3 and 1 (each within the scatter of the next).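

In this assay, methyl in place of hydrogen on an aromatic carbon gives a 3.9-fold lower number from compound 1 to compound 4 (0.59 log units; beyond the scatter), a step beyond the scatter. Going by these compounds alone, this is the first measured change on the shared core, and it shows that a single added carbon here, with the 4-methylphenyl group untouched, is enough to move the number. Nothing available bears on the cause of this step.

As far as these compounds go, whether an amine or a methoxy group on this carbon would shift the number in the same direction remains open. So does the size of the methyl step on the pyridine analogues, compound 2 and compound 3.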